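Replacing sulfamoyl with methoxy on the shared core

The source may report more compounds than this note shows. Statements on the series, on what has been measured and on what is new or still open speak of the compounds shown alone.

In a physicochemical assay for solubility (on this read-out higher numbers stand for higher solubility and lower numbers for lower solubility), compound 1 (`NS(=O)(=O)c1ccc(NC(=O)c2cc(Cl)ccc2O)cc1`) gives > 48 ug/mL as a limit of the assay, not as a number. Compound 2 (`O=C(Nc1cc([N+](=O)[O-])c(Cl)cc1F)c1cc(Cl)ccc1O`) gives 8 ug/mL and compound 3 (`O=C(Nc1c(F)cccc1F)c1cc(Cl)ccc1O`) gives 16 ug/mL as true numbers, and these two lie within the scatter of each other. Compound 1 therefore stands only as a limit, and no exact gap to the other two can be read.

Compound 4 (`COc1ccc(NC(=O)c2cc(Cl)ccc2O)cc1`) carries methoxy in place of sulfamoyl on an aromatic carbon, para to a large group (methoxy in place of sulfamoyl on an aromatic carbon). Going by the values given here, no measured pair isolates this change. Among the compounds with values here, neither compound 2 at 8 ug/mL nor compound 3 at 16 ug/mL carries sulfamoyl, and these two readings are the only guide to where a compound without it may fall. In this assay, as far as these compounds go, a downward step beyond the scatter is expected (an at least 3.2-fold lower number from compound 1 to compound 4 (0.50 log units; beyond the scatter)), though its true size stays open while the starting point is only a limit. The estimate for compound 4 is 15 ug/mL with 5 ug/mL to 45 ug/mL as the expected range.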

Compound 4, solubility: 2.8 ug/mL
For compound 4 the middle estimate is 5.4-fold (0.73 log units) above the measured one; measured number below the stated range.
By their numbers in this assay, from the lowest: compound 4; then compounds 2 and 3 (each within the scatter of the next). At a limit, above all of these: compound 1.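

Methoxy in place of sulfamoyl on an aromatic carbon, para to a large group, now stands as a single change on the shared core, and in this assay it gives an at least 17-fold lower number from compound 1 to compound 4 (1.23 log units; beyond the scatter). Going by these compounds alone, the earlier compounds held no pair differing in one place, so this is the first step that can be read at this position, and it lies beyond the scatter. Compound 1 stands as a limit and not as a number, so the step has a floor and no upper end: the limit of > 48 ug/mL in this assay, at which 1 of the 4 values shown sits.

Only sulfamoyl and methoxy are shown at this position on the shared core, so the step describes this one pair and no trend across groups. As far as these compounds go, how an amine, a carboxylic acid or a longer chain would read at the same place stays open.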